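This account rests on a few compounds, and the source may have more. Where it says the series, first, only, none or still open, it means among the compounds named here.

Compounds measured in a functional assay on HeLa cells (Homo sapiens) for inhibition, read by CCK-8 assay, with a stated time of 4 days; on this read-out higher numbers stand for weaker inhibition and lower numbers for stronger inhibition:
- Compound 1 `COc1cc(C(=O)O)ccc1NC(=O)[C@@H]1N[C@@H](CC(C)(C)C)[C@](CNCc2ccncc2)(c2ccc(Cl)cc2F)[C@H]1c1cccc(Cl)c1F`: 7370 nM
- Compound 2 `COc1cc(C(=O)O)ccc1NC(=O)[C@@H]1N[C@@H](CC(C)(C)C)[C@](CNCc2ccc(O)cc2)(c2ccc(Cl)cc2F)[C@H]1c1cccc(Cl)c1F`: 6560 nM
- Compound 3 `COc1cc(C(=O)O)ccc1NC(=O)[C@@H]1N[C@@H](CC(C)(C)C)[C@](CNCc2ccccn2)(c2ccc(Cl)cc2F)[C@H]1c1cccc(Cl)c1F`: 9900 nM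

Compound 3, at 9900 nM, stands within the scatter of both other compounds, so the three cannot be told apart. Compound 4 `COc1cc(C(=O)O)ccc1NC(=O)[C@@H]1N[C@@H](CC(C)(C)C)[C@](CNCc2cccnc2)(c2ccc(Cl)cc2F)[C@H]1c1cccc(Cl)c1F` differs from compound 3 by one exchange, pyridin-3-yl in place of pyridin-2-yl on a saturated chain carbon bound to an amine nitrogen. The measured exchanges at that place are all small: a 1.3-fold higher number from compound 1 to compound 3 (0.13 log units; within the scatter), a 1.5-fold higher number from compound 2 to compound 3 (0.18 log units; within the scatter) and a 1.1-fold lower number from compound 1 to compound 2 (0.05 log units; within the scatter). No step beyond the scatter is therefore expected in this assay, and the data suggest no clear direction. The estimated change is a 1.2-fold lower number from compound 3 to compound 4 (0.09 log units; within the scatter). For compound 4 the estimate is 8000 nM, with an expected range from 4500 nM to 14000 nM.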

Compound 4, half-maximal inhibitory concentration: 9900 nM
The estimate for compound 4 lay 1.2-fold (0.09 log units) below the measured number; the range from low to high includes it.
By their numbers in this assay, from the lowest: compounds 2, 1, 3 and 4 (each within the scatter of the next).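

With pyridin-3-yl on the saturated chain carbon bound to an amine nitrogen, all three pyridinyl attachments can now be compared in this assay, and the exchange for pyridin-2-yl gives no change at the digits printed from compound 3 to compound 4 (within the scatter). The exchanges from the other two groups, a 1.3-fold higher number from compound 1 to compound 4 (0.13 log units; within the scatter) and a 1.5-fold higher number from compound 2 to compound 4 (0.18 log units; within the scatter), also stay within the scatter, so the point of attachment of the pyridine ring does not separate these compounds here. No evidence on hand bears on this result. Going by these compounds, it remains open whether a carboxylic acid, a primary amine or a longer alkyl chain at this place would give a step beyond the scatter.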